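This account rests on a few compounds, and the source may have more. Where it says the series, first, only, none or still open, it means among the compounds named here.

Among the three compounds measured in a functional assay on CHOK cells for antagonist activity at growth hormone secretagogue receptor type 1 (Homo sapiens), read by calcium flux (on this read-out lower numbers stand for stronger inhibition and higher numbers for weaker inhibition), compound 3 `CC(C)(C)CNc1ccc(-c2c(N)nc(N)nc2COCc2ccccc2)cc1` gives the highest number, 700 nM. Compound 1 `Nc1nc(N)c(-c2ccc(NCc3ccnc(Cl)c3)cc2)c(COCc2ccccc2)n1` gives 3.6 nM, and compound 2 `Nc1nc(N)c(-c2ccc(NCc3ccncc3)cc2)c(COCc2ccccc2)n1` gives 86 nM. The step from compound 1 to compound 2 is a 24-fold higher number from compound 1 to compound 2 (1.38 log units; beyond the scatter), and the two steps that end at compound 3 are both upward: a 190-fold higher number from compound 1 to compound 3 (2.29 log units; beyond the scatter) and an 8.1-fold higher number from compound 2 to compound 3 (0.91 log units; beyond the scatter).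

Compound 4 `N#Cc1ccc(COc2ccc(-c3c(N)nc(N)nc3COCc3ccccc3)cc2)cc1` has not yet been measured in this assay. It differs from compound 3 in one place: (4-cyanobenzyl)oxy in place of neopentylamino on an aromatic carbon. For the measured compounds named here, the steps that bear on this change are the two that remove an aromatic ring from the side chain, from compound 1 and from compound 2 to compound 3, and both were large. Going by the values given here, compound 4 brings an aromatic ring back into that chain, though through an oxygen rather than a nitrogen, for which no measured step exists. A downward step, a 12-fold lower number from compound 3 to compound 4 (1.07 log units; beyond the scatter), is therefore expected, though its size is uncertain. In this assay compound 4 is estimated at 60 nM, within a range from 6 nM to 600 nM.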

Compound 4, half-maximal inhibitory concentration: 3610 nM
Beside the measured number, compound 4's estimate is 60-fold (1.78 log units) below it; the measured number lies above the stated range.
By their numbers in this assay, from the lowest: compound 1; then compound 2; then compound 3; then compound 4.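

Putting an aromatic ring back into this side chain does not by itself restore strength in this assay, since (4-cyanobenzyl)oxy in place of neopentylamino gives a 5.2-fold higher number from compound 3 to compound 4 (0.71 log units; beyond the scatter) and leaves the ring-bearing compound 4 weaker than the ring-free compound 3. The gap is wider against the side chains that keep the nitrogen and carry a pyridine ring, with a 42-fold higher number from compound 2 to compound 4 (1.62 log units; beyond the scatter) and a 1000-fold higher number from compound 1 to compound 4 (3.00 log units; beyond the scatter) as the result. Nothing available gives a measured reason for these rises.

This change swaps the linking nitrogen for oxygen and the pyridine ring for a cyanophenyl ring at once, so the shown compounds cannot say which of these matters. A (4-cyanobenzyl)amino group at this aromatic carbon would separate the linking atom from the ring.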